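A smaller aromatic group on compound 2

A few compounds are considered here, and "the series" means these few. Any claim that something is new, unique, unknown or untested is made for them only; others in the source may bear on it.

Measured in an ADME assay on microsomes from liver (Rattus norvegicus) for metabolic stability; a lower number here means that the compound disappears faster, a higher number that the compound lasts longer:
- Compound 1 `Cc1nnc(-c2ccc(Nc3cc(C)c4ncn(CC5CC5)c4n3)nc2)o1`: > 1.66 h (a limit, not a number)
- Compound 2 `Cc1cc(Nc2ccc(-c3cnc4ncccn34)cn2)nc2c1ncn2CC1CC1`: 0.467 h

Among the compounds with values here, compound 2 holds the only exact number so far in this assay, at 0.467 h. Going by these compounds, compound 1 sits at a limit, so how far it lies from compound 2 stays open.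

Compound 3 `Cc1cc(Nc2ccc(-n3ccnc3)cn2)nc2c1ncn2CC1CC1` differs from compound 2 in one place: a group of 5 heavy atoms (3 carbon, 2 nitrogen; one five-membered aromatic ring with 2 hetero atoms) in place of a group of 9 heavy atoms (6 carbon, 3 nitrogen; one five-membered aromatic ring with 2 hetero atoms, one six-membered aromatic ring with 2 hetero atoms), on an aromatic carbon.

Within the data shown here, one measured step bears on this change: an at least 3.5-fold lower number from compound 1 to compound 2 (0.55 log units; beyond the scatter). That step lies beyond the scatter and brought in the same group that now leaves. Removing this group could therefore raise the number, but 1H-imidazol-1-yl is not the group carried by compound 1, so only part of an at least 3.5-fold lower number from compound 1 to compound 2 (0.55 log units; beyond the scatter) is expected to return. A small rise, possibly within the scatter, is expected: a 1.4-fold higher number from compound 2 to compound 3 (0.14 log units; within the scatter). Compound 3 is estimated at 0.65 h, with an expected range of 0.3 h to 1.5 h.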

Compound 3, half-life: 0.45 h
For compound 3 the middle estimate is 1.4-fold (0.16 log units) above the measured one, within the range that was stated.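

In this assay, putting 1H-imidazol-1-yl in place of the larger group of two aromatic rings on this aromatic carbon gives a 1.0-fold lower number from compound 2 to compound 3 (0.02 log units; within the scatter). Among these compounds, then, a much smaller group at this place makes no readable difference to how long the compound lasts. The gap to the 5-methyl-1,3,4-oxadiazol-2-yl group of compound 1 also stands with the smaller group: an at least 3.6-fold lower number from compound 1 to compound 3 (0.56 log units; beyond the scatter), so that gap does not depend on the larger group of compound 2 alone.

Going by these compounds, compound 1 stands at a limit and not a number, so the full size of that gap stays open: the limit of > 1.66 h in this assay, at which 1 of the 3 values shown sits. Also open is what a nitrile or a simple amide at this place would give in this assay.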